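The compounds below may be only part of what the source reports. "The series", "measured", "known", "first", "only" and "open" are said of these compounds alone.

Compound 1 `CC(=O)Oc1ccccc1C(=O)O[C@H]1CO[C@H]2[C@@H]1OC[C@H]2OC(=O)c1cccc(C)c1` stands second highest of the three numbers gathered so far in an ADME assay on a cell-free system (plasma, Homo sapiens) for metabolic stability, with Plasma (Rattus norvegicus) as the target, read by HPLC, at pH 7.4 (on this read-out higher numbers stand for a longer-lived compound and lower numbers for a shorter-lived compound), where compound 1 gives 0.165 h. Compound 3 `CC(=O)Oc1ccccc1C(=O)O[C@H]1CO[C@H]2[C@@H]1OC[C@H]2OC(=O)c1ccccc1OC(=O)c1ccccc1` gives 0.385 h, the higher of the pair; compound 2 `COc1cccc(C(=O)O[C@@H]2CO[C@H]3[C@@H]2OC[C@@H]3OC(=O)c2ccccc2OC(C)=O)c1` gives 0.0525 h, the lowest of the set. Among the compounds with values here, the one single-site step recorded, a 3.1-fold lower number from compound 1 to compound 2 (0.50 log units; beyond the scatter), is also the only change seen on the (3-methylphenyl)carbonyl group.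

Compound 4 `CC(=O)Oc1ccccc1C(=O)O[C@H]1CO[C@H]2[C@@H]1OC[C@H]2OC(=O)c1cc(C)nc(Cl)c1` is the next step from compound 1: 2-chloro-6-methylpyridin-4-yl in place of 3-methylphenyl on a carbonyl carbon. Within the data shown here, it sits on the same (3-methylphenyl)carbonyl group that carried the methoxy change, but it swaps the whole ring rather than one substituent, and no compound with a pyridine ring has been measured here. Among the measured compounds shown here, the methoxy step was modest and downward; a ring swap of this kind has no precedent in the set, so its direction cannot be read from the data. For compound 4 the expected step is a 1.1-fold lower number from compound 1 to compound 4 (0.04 log units; within the scatter), with the range kept wide. The estimate for compound 4 in this assay is 0.15 h, between 0.05 h and 0.45 h.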

Compound 4, half-life: 0.0193 h
Compound 4: middle estimate off by 7.8-fold (0.89 log units), on the high side; the whole stated range lies above it.
By their numbers in this assay, from the lowest: compound 4; then compound 2; then compound 1; then compound 3.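

In this assay, replacing the whole ring on this carbonyl carbon moves the half-life further down the scale, with an 8.5-fold lower number from compound 1 to compound 4 (0.93 log units; beyond the scatter), the same direction as the earlier methoxy change, a 3.1-fold lower number from compound 1 to compound 2 (0.50 log units; beyond the scatter). The 2-chloro-6-methylpyridin-4-yl group also falls short of 3-methoxyphenyl at this place, with a 2.7-fold lower number from compound 2 to compound 4 (0.43 log units; beyond the scatter), so both aromatic carbon-only rings that can be compared directly with it give longer half-lives. No measured information on the origin of this drop is available.

The compounds shown leave open whether the ring nitrogen, the chlorine or their combination accounts for the step. Also open, as far as these compounds go, is how an amine or a carboxylic acid on the ring at this place would read in this assay.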